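Aryl swap on the shared core: compound 3 to compound 4

The compounds below may be only part of what the source reports. "The series", "measured", "known", "first", "only" and "open" are said of these compounds alone.

Measured so far in a functional assay on MCF7 cells (Homo sapiens) for inhibition, read by CCK-8 assay, with a stated time of 48 h; a higher number here means a weaker inhibitor, a lower number a stronger inhibitor:
compound 1, `COc1ccc(-c2cc3nccc(-c4cc(OC)c(OC)c(OC)c4)n3n2)cc1N`, gives 27 nM
compound 2, `COc1cc(-c2ccnc3cc(-c4ccc(C)cc4)nn23)cc(OC)c1OC`, gives 47 nM
compound 3, `COc1cc(-c2ccnc3cc(-c4ccc5cc[nH]c5c4)nn23)cc(OC)c1OC`, gives 23 nM

Within the data shown here, compound 3 holds the lowest number of the three, though compound 1 lies within the scatter of it; only the step of a 2.0-fold lower number from compound 2 to compound 3 (0.31 log units; beyond the scatter) is beyond the scatter. Compound 4, `COc1cc(-c2ccnc3cc(-c4ccc(C(C)(C)C)cc4)nn23)cc(OC)c1OC`, differs from compound 3 in one place: 4-(tert-butyl)phenyl in place of 1H-indol-6-yl on an aromatic carbon. The step that bears on this is a 2.0-fold lower number from compound 2 to compound 3 (0.31 log units; beyond the scatter), where 1H-indol-6-yl replaced 4-methylphenyl and the number fell; the other steps, a 1.7-fold higher number from compound 1 to compound 2 (0.24 log units; within the scatter) and a 1.2-fold lower number from compound 1 to compound 3 (0.07 log units; within the scatter), stayed within the scatter. Among the measured compounds shown here, no measured step covers 4-(tert-butyl)phenyl itself. Returning to a plain alkylphenyl is therefore expected to undo the modest gain, a step estimated as a 2.4-fold higher number from compound 3 to compound 4 (0.38 log units; beyond the scatter). Compound 4 is estimated at 55 nM, with a range of 22 nM to 140 nM.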

Compound 4, half-maximal inhibitory concentration: > 10000 nM
Compound 4: no number, only a limit; the forecaster's own chance of this, stated with the estimate: 3%; middle value at least 180-fold (2.25 log units) from the limit.
By their numbers in this assay, from the lowest: compounds 3, 1 and 2 (each within the scatter of the next, the first and the last beyond it). At a limit, above all of these: compound 4.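

In this assay compound 4 gives no number, only a limit: the limit of > 10000 nM in this assay, at which 1 of the 4 values shown sits.

Among these compounds, this position, on an aromatic carbon of the five-membered ring, does not accept every aryl group: the earlier compounds differed only modestly, whereas tert-butyl in place of methyl alone gives an at least 210-fold higher number from compound 2 to compound 4 (2.32 log units; beyond the scatter). The swaps from the other two aryl groups are of the same order, an at least 430-fold higher number from compound 3 to compound 4 (2.63 log units; beyond the scatter) and an at least 370-fold higher number from compound 1 to compound 4 (2.56 log units; beyond the scatter).

On these data alone, whether ethyl or isopropyl in place of tert-butyl would keep a measurable number in this assay stays open. The limit also leaves the full size of these steps unknown.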